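This account rests on a few compounds, and the source may have more. Where it says the series, first, only, none or still open, it means among the compounds named here.

Measured so far in a functional assay for inhibition of sodium/hydrogen exchanger (Oryctolagus cuniculus); a lower number here means a stronger inhibitor, a higher number a weaker inhibitor:
compound 1 `Cc1c(C(=O)N=C(N)N)cc(S(C)(=O)=O)c(Cl)c1[N+](=O)[O-]` gives 44 nM
compound 2 `Cc1c(C(=O)N=C(N)N)ccc(Cl)c1S(C)(=O)=O` gives 1300 nM
compound 3 `CCc1cc(C)c(C(=O)N=C(N)N)cc1S(C)(=O)=O` gives 4.8 nM

Compound 3 has the lowest number of the three and is therefore the strongest inhibitor among them: its gap to compound 1 and its far wider gap to compound 2 both lie beyond the usual scatter of this assay. All three share the same core, which carries the acyl-guanidine and a methylsulfonyl group, and differ only in what else sits on the ring.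

Compound 4 `Cc1cc(-c2cc(Cl)cc(Cl)c2)c(S(C)(=O)=O)cc1C(=O)N=C(N)N` has not yet been measured in this assay. It differs from compound 3 in one place: 3,5-dichlorophenyl in place of ethyl on an aromatic carbon. For the measured compounds named here, none of the measured compounds shows what happens when a short chain gives way to a ring at this position, so no measured step guides the expectation directly. The incoming group is far larger than the one it replaces, and the value of compound 3 at 4.8 nM leaves little room for the number to fall much further. The expected result is a modest rise in the number, that is a somewhat weaker inhibitor, though a value close to compound 3 would not be surprising. For compound 4 the expected step is a 3.1-fold higher number from compound 3 to compound 4 (0.49 log units; beyond the scatter). Compound 4 is estimated at 15 nM, with a likely range from 2.5 nM to 90 nM.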

Compound 4, half-maximal inhibitory concentration: 130 nM
Compound 4: middle estimate off by 8.7-fold (0.94 log units), on the low side; measured number outside the range, above it.
By their numbers in this assay, from the lowest: compound 3; then compound 1; then compound 4; then compound 2.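

In this assay, putting 3,5-dichlorophenyl in place of ethyl on this aromatic carbon, ortho to a methylsulfonyl group, gives a 27-fold higher number from compound 3 to compound 4 (1.43 log units; beyond the scatter). For the compounds shown here, this is the first direct reading of this position, and it shows that the group held there matters greatly: a change from a two-carbon chain to a ring-bearing group of 8 heavy atoms, with no hydrogen-bond donors or acceptors and no net charge on either side, is enough to produce a large loss of inhibition. No measurement available here explains the size of this step, so the data record the change in potency without giving its cause.

The compounds shown leave open whether the loss comes from the aromatic ring itself or from its two chlorine atoms, a question that a plain phenyl group at the same place could help settle. They also leave open how a longer chain such as propyl, or a smaller polar group such as an amine, would fare on this carbon.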